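Swapping one sulfonyl group: what stability to expect

The source may hold more compounds than are shown below. What is called first, only, known or untested is meant among the compounds shown, and "the series" means these compounds.

In an ADME assay on microsomes from liver (Rattus norvegicus) for metabolic stability, read by LC-MS, using NADPH, with a stated time of 30 min, tested at 0.1 uM (a lower number here means that less of the compound is left, a higher number that more of the compound is left), compound 1 `CS(=O)(=O)Nc1ccc2nccc(-c3ccncc3)c2n1` shows 94% remaining, compound 2 `O=S(=O)(CCO)c1cccc(-c2ccc3nccc(-c4ccncc4)c3n2)c1` shows 59% remaining and compound 3 `O=S(=O)(NCCO)c1cccc(Nc2ccc3nccc(-c4ccncc4)c3n2)c1` shows 58% remaining. Compound 2 and compound 3 lie within the usual scatter of each other, so these two cannot be told apart. Compound 2 stands well below compound 1, and that gap lies beyond the scatter.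

Compound 4 `C[C@@H]1CN(S(=O)(=O)c2cccc(-c3ccc4nccc(-c5ccncc5)c4n3)c2)C[C@H](C)N1` keeps the rest of compound 2 but carries 3,5-dimethylpiperazin-1-yl in place of 2-hydroxyethyl on a sulfonyl sulfur. Going by the values given here, no measured pair here shows this swap, so its direction remains open. The expected change is modest, an estimated step of a number 4 percentage points lower from compound 2 to compound 4 (within the scatter) that stays within the scatter. This expectation starts from compound 2 at 59% and draws some support from compound 3, which has a different sulfonyl substituent and shows 58% remaining. Compound 4 is estimated at 55% (range 30% to 78%).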

Compound 4, percent of the compound remaining: 36%
Beside the measured number, compound 4's estimate is 19 percentage points above it; the measured number falls inside the stated range.
By their numbers in this assay, from the lowest: compound 4; then compounds 3 and 2 (each within the scatter of the next); then compound 1.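

In this assay, 3,5-dimethylpiperazin-1-yl in place of 2-hydroxyethyl on a sulfonyl sulfur gives a number 23 percentage points lower from compound 2 to compound 4 (beyond the scatter) and so moves the result by more than repeat measurements would. Among the compounds shown, only compound 2 and compound 4 differ in one place, so this pair alone shows that the group on this sulfonyl sulfur can change how much compound is left. Nothing measured here explains the change.

The swap alters several things at once, so this single step cannot separate the contribution of the six-membered ring from that of its two methyl groups or its two defined stereocentres. On these data alone, it also remains open where an unsubstituted piperazine, a morpholine or a longer hydroxyalkyl chain on the same sulfur would fall.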